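The source may report more compounds than this note shows. Statements on the series, on what has been measured and on what is new or still open speak of the compounds shown alone.

Compound 1 `COc1ccc(-c2nc(SC)nc(NCCCCNc3ccnc4cc(Cl)ccc34)c2C#N)cc1`: in an ADME assay on MDCK cells (Canis lupus familiaris) for cytotoxicity, read by microscopy (a lower number here means that less compound is tolerated, a higher number that more compound is tolerated), compound 1 gives 20000 nM.
Compound 2 `COc1cc(-c2nc(SC)nc(NCCCCNc3ccnc4cc(Cl)ccc34)c2C#N)cc(OC)c1OC`: in this assay compound 2 gives 4000 nM.

Of these two numbers, compound 2 holds the lower one, meaning less of it is tolerated by the cells. Going by the values given here, the only measured step connects the pair: a 5.0-fold lower number from compound 1 to compound 2 (0.70 log units; beyond the scatter), a modest change. Compound 2 carries 3,4,5-trimethoxyphenyl on the aromatic carbon where compound 1 carries 4-methoxyphenyl.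

Compound 3 `CSc1nc(NCCCCNc2ccnc3cc(Cl)ccc23)c(C#N)c(-c2ccc(C)cc2)n1` now carries a smaller group at that same carbon: 4-methylphenyl in place of 3,4,5-trimethoxyphenyl on an aromatic carbon. Among the compounds with values here, because the one step on record, a 5.0-fold lower number from compound 1 to compound 2 (0.70 log units; beyond the scatter), went with the arrival of the 3,4,5-trimethoxyphenyl group, its departure in favour of a group that resembles the 4-methoxyphenyl of compound 1 points back toward the number of compound 1. Compound 3 is therefore expected to give roughly 15000 nM, plausibly between 5000 nM and 40000 nM. The expected step is a 3.8-fold higher number from compound 2 to compound 3 (0.57 log units; beyond the scatter), upward rather than none.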

Compound 3, minimum cytotoxic concentration: 20000 nM
Estimate against measurement, compound 3: 1.3-fold (0.12 log units) below; low and high end bracket the measured number.
By their numbers in this assay, from the lowest: compound 2; then compounds 1 and 3 (each within the scatter of the next).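

Putting 4-methylphenyl in place of 3,4,5-trimethoxyphenyl reverses the earlier drop (a 5.0-fold higher number from compound 2 to compound 3 (0.70 log units; beyond the scatter)), so the same carbon can move the number in either direction, not only downward. The swap of methyl for methoxy on the phenyl ring leaves this assay unmoved (no change at the digits printed from compound 1 to compound 3 (within the scatter)), which means that among these three compounds only the 3,4,5-trimethoxyphenyl group stands apart, while 4-methoxyphenyl and 4-methylphenyl cannot be told apart. Nothing available here explains why the 3,4,5-trimethoxyphenyl group goes with the lower number.

On these data alone, it remains open whether one added methoxy group, as in 3,4-dimethoxyphenyl, would already lower the number or whether all three are needed. An unsubstituted phenyl or a 4-chlorophenyl group at this carbon would show whether the flat result extends beyond methyl and methoxy.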